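Notes on a two-point series and a planned aniline analogue

A few compounds are considered here, and "the series" means these few. Any claim that something is new, unique, unknown or untested is made for them only; others in the source may bear on it.

Compound 1 `COc1cc(-c2cc3nccc(-c4c[nH]c5ccccc45)n3n2)cc(OC)c1OC`: > 10000 nM
Compound 2 `COc1cc(-c2ccnc3cc(-c4ccc5cc[nH]c5c4)nn23)cc(OC)c1OC`: 55 nM

In a functional assay on B16-F0 cells (Mus musculus) for inhibition, read by CCK-8 assay, with a stated time of 48 h (a lower number here means a stronger inhibitor, a higher number a weaker inhibitor), compound 1 gives only a limit, > 10000 nM, with no number behind it (the limit of > 10000 nM in this assay, at which 1 of the 2 values shown sits). Among the compounds with values here, compound 2 gives 55 nM in this assay and so holds the only real number in the set. Within the data shown here, the remaining entry, that of compound 1, is a limit, which leaves no measured step to lean on.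

Compound 3 `COc1ccc(-c2cc3nccc(-c4cc(OC)c(OC)c(OC)c4)n3n2)cc1N` is the next candidate. Against compound 2 the change is 3-amino-4-methoxyphenyl in place of 1H-indol-6-yl on an aromatic carbon, so one donor is kept while two acceptors arrive and the five-membered ring is lost.

Among the measured compounds shown here, with no measured step between neighbours, the expectation for compound 3 rests on the two structures alone; the step is expected to be a loss of potency of a 15-fold higher number from compound 2 to compound 3 (1.16 log units; beyond the scatter), clearly beyond the scatter. Compound 3 is estimated at 800 nM, with a range from 100 nM to 10000 nM.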

Compound 3, half-maximal inhibitory concentration: 88 nM
Beside the measured number, compound 3's estimate is 9.1-fold (0.96 log units) above it, and the stated range ends above it.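

At this aromatic carbon of the five-membered aromatic ring, 3-amino-4-methoxyphenyl in place of 1H-indol-6-yl gives a 1.6-fold higher number from compound 2 to compound 3 (0.20 log units; within the scatter) in this assay, so the two groups cannot be told apart in this read-out. The five-membered ring of the indole is therefore not needed to keep a value of this order for this pair, since a single six-membered aromatic ring of carbon only, with the same donor count and two acceptors added, serves within the scatter. Nothing measured here gives a cause for this result.

From the compounds shown here alone, what the amine and the methoxy each contribute remains open. A hydroxyl in place of the amine, or an unsubstituted phenyl at this carbon, would separate the two.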